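The compounds below may be only part of what the source reports. "The series", "measured", "known", "first", "only" and "open" are said of these compounds alone.

The three measured compounds, with their half-maximal inhibitory concentrations:

- compound 1, `CCOc1ccc(NC(=O)c2c(N)n[nH]c2Nc2ccccc2)cc1`: 4320 nM
- compound 2, `CCOc1ccc(-n2nnc3n[nH]c(NC)c3c2=O)cc1`: 7010 nM
- compound 3, `CCOc1ccc(NC(=O)CC#N)cc1`: 21500 nM

All three were tested in a functional assay on Huh-7 cells (Homo sapiens) for cytotoxicity, read by resazurin assay, with a stated time of 48 h; on this read-out higher numbers stand for weaker inhibition and lower numbers for stronger inhibition. Compound 1 has the lowest of the three numbers, but its nearest neighbour, compound 2, sits within the usual scatter of it, so the two cannot be ordered. The gap to compound 3 lies beyond the scatter: the number for compound 3 is clearly higher than that for compound 1.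

The next compound, compound 4 `C=CCNc1[nH]nc(N)c1C(=O)Nc1ccc(OCC)cc1`, keeps the core of compound 1 and alters one attachment: allyl in place of phenyl on a nitrogen on an aromatic ring. For the measured compounds named here, no measured pair here changes the same nitrogen, so there is no directly comparable step to lean on. The swap replaces a ring with a short chain at the same position, and the rest of the molecule is untouched. For a cytotoxicity read-out of this kind, a change of this sort is expected to move the number little; the expected step of a 1.3-fold higher number from compound 1 to compound 4 (0.10 log units; within the scatter) is small, most likely towards a slightly higher number, and quite possibly none beyond the scatter. Compound 4 is therefore estimated at 5500 nM, with a range from 2000 nM to 15000 nM.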

Compound 4, half-maximal inhibitory concentration: 22000 nM
Beside the measured number, compound 4's estimate is 4.0-fold (0.60 log units) below it, and the stated range ends below it.
By their numbers in this assay, from the lowest: compounds 1 and 2 (each within the scatter of the next); then compounds 3 and 4 (each within the scatter of the next).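

Swapping anilino for allylamino on the nitrogen on the aromatic ring gives, in this assay, a 5.1-fold higher number from compound 1 to compound 4 (0.71 log units; beyond the scatter) and so shows that the group at this position does register in the read-out, which no earlier pair of compounds could show. The change puts allyl, with 3 heavy atoms and a double bond outside aromatic rings, in place of phenyl, with 6 heavy atoms in one six-membered aromatic ring, while neither group carries a hydrogen-bond donor, a hydrogen-bond acceptor or a net charge, so those counts do not distinguish the two groups. No measurement here accounts for the shift.

The compounds shown leave open whether the loss of the aromatic ring, the smaller group or the double bond of allyl matters most, as all three changes arrive together in this single step. A saturated propyl chain or a cyclohexyl ring on this nitrogen would begin to pull these apart, and a phenyl ring carrying a fluorine would show how much change the ring itself allows.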